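Chain length and aortic inhibition in sulfonamide acids

A few compounds are considered here, and "the series" means these few. Any claim that something is new, unique, unknown or untested is made for them only; others in the source may bear on it.

Measured compounds:
compound 1, `O=C(O)CCCCCCNS(=O)(=O)c1ccccc1`, 55300 nM
compound 2, `O=C(O)CCCCCCCNS(=O)(=O)c1ccccc1`, 2800 nM
compound 3, `O=C(O)CCCCCCCCCCNS(=O)(=O)c1ccccc1`, 4600 nM

All three were tested in a functional assay (aorta) for inhibition, with Rattus norvegicus as the target; on this read-out lower numbers stand for stronger inhibition and higher numbers for weaker inhibition. Compound 2 differs from compound 1 by carboxymethyl in place of carboxy on a saturated chain carbon, six bonds along the chain from a sulfonamide nitrogen, and this gives a 20-fold lower number from compound 1 to compound 2 (1.30 log units; beyond the scatter). Compound 3 differs from compound 1 by 4-carboxybutyl in place of carboxy on a saturated chain carbon, six bonds along the chain from a sulfonamide nitrogen, with a 12-fold lower number from compound 1 to compound 3 (1.08 log units; beyond the scatter). Between compound 2 and compound 3 the reading is a 1.6-fold higher number from compound 2 to compound 3 (0.22 log units; within the scatter), so those two cannot be told apart.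

Compound 4, `O=C(O)CCCCCCCCCCCNS(=O)(=O)c1ccccc1`, has not yet been measured. It differs from compound 3 by carboxymethyl in place of carboxy on a saturated chain carbon, ten or more bonds along the chain from a sulfonamide nitrogen. Going by the values given here, this is the same kind of change as the one from compound 1 to compound 2, but the place is not the same: there the change sits six bonds along the chain from a sulfonamide nitrogen, here it sits at the place named in the difference from compound 3 to compound 4 just given. The large step seen from compound 1 to compound 2 came at the short end of the series, whereas compound 2 and compound 3 already lie within the scatter of each other, so a further lengthening is expected to do little. Compound 4 is therefore expected to give about 5500 nM in this assay, somewhere between 1500 nM and 20000 nM, which means an expected step of a 1.2-fold higher number from compound 3 to compound 4 (0.08 log units; within the scatter).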

Compound 4, half-maximal inhibitory concentration: 6400 nM
Beside the measured number, compound 4's estimate is 1.2-fold (0.07 log units) below it; the range from low to high includes it.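

In this assay, the change from carboxy to carboxymethyl does not carry over from the short end of the series to the long end, since on the longer chain it gives a 1.4-fold higher number from compound 3 to compound 4 (0.14 log units; within the scatter), a step that cannot be told from repeat-measurement noise: the same change on two cores in this assay, a 20-fold lower number (1.30 log units; beyond the scatter) from compound 1 to compound 2 and a 1.4-fold higher number (0.14 log units; within the scatter) from compound 3 to compound 4, 27-fold (1.44 log units) apart, beyond the scatter of two such steps. The longer replacement, 4-carboxybutyl in place of carboxy, also reads differently on two cores, giving a 2.3-fold higher number from compound 2 to compound 4 (0.36 log units; beyond the scatter) on the core of compound 2, whereas it lowered the number on the core of compound 1: the same change on two cores in this assay, a 12-fold lower number (1.08 log units; beyond the scatter) from compound 1 to compound 3 and a 2.3-fold higher number (0.36 log units; beyond the scatter) from compound 2 to compound 4, 27-fold (1.44 log units) apart, beyond the scatter of two such steps. The longest chain still keeps much of the advantage over the shortest, with an 8.6-fold lower number from compound 1 to compound 4 (0.94 log units; beyond the scatter), so these results show that the size and direction of a chain extension depend on the core that receives it, but they do not show why.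

The compounds shown leave open how chains of intermediate length, falling between those of compound 2 and compound 3, would read, and whether a still longer chain would raise the number further. They also leave open whether the carboxylic acid itself matters, which an amide or an ester in its place could test.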